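The compounds below may be only part of what the source reports. "The series", "measured", "known", "first", "only" and "open" are said of these compounds alone.

Compound 1 `Cc1c(OCCCCOc2ccc(C(=O)O)cc2F)ccc(C(=O)CC2CCCC2)c1O` gives > 10000 nM in an assay on HEK293 cells for positive allosteric modulation of metabotropic glutamate receptor 3 (Rattus norvegicus), read by thallium flux, with a stated time of 2.5 min; on this read-out higher numbers stand for an effect only at larger amounts of compound and lower numbers for an effect already at smaller amounts.
Compound 2 `Cc1c(OCCCCOc2ccc(C(=O)O)cc2Cl)ccc(C(=O)CC2CCCC2)c1O` gives > 10000 nM in this assay.
Compound 3 `COc1ccc(C(=O)O)cc1OCCCCOc1ccc(C(=O)CC2CCCC2)c(O)c1C` gives 1020 nM in this assay.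

The value of compound 1 is a limit of the assay, not a number. The value of compound 2 is likewise a limit. Among the compounds with values here, compound 3 is thus the only compound here with a number. Both measured steps run toward it, an at least 9.8-fold lower number from compound 1 to compound 3 (0.99 log units; beyond the scatter) and an at least 9.8-fold lower number from compound 2 to compound 3 (0.99 log units; beyond the scatter), each set by the limit of > 10000 nM in this assay, at which 2 of the 3 values shown sit. Compound 4 `Cc1c(OCCCCOc2ccc(C(=O)O)c(Cl)c2)ccc(C(=O)CC2CCCC2)c1O` is not yet measured and differs from compound 3 by 4-carboxy-3-chlorophenyl in place of 5-carboxy-2-methoxyphenyl on an oxygen on a saturated carbon. Compound 1 and compound 2 also carry a 4-carboxy group together with a ring halogen and sit at the limit of > 10000 nM in this assay, at which 2 of the 3 values shown sit. The step of a 7.8-fold higher number from compound 3 to compound 4 (0.89 log units; beyond the scatter) is therefore expected to undo most of the gain. Compound 4 is expected to give 8000 nM in this assay, with a range from 2500 nM to 30000 nM.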

Compound 4, half-maximal effective concentration: 2250 nM
Compound 4: the middle estimate sits 3.6-fold (0.55 log units) above what was measured; the measured number lies below the stated range.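

The 4-carboxy group with a ring halogen does not by itself lose the effect, since the 4-carboxy-3-chlorophenyl group gives an at least 4.4-fold lower number from compound 2 to compound 4 (0.64 log units; beyond the scatter) and an at least 4.4-fold lower number from compound 1 to compound 4 (0.64 log units; beyond the scatter). Both of these steps rest on a limit, not a number: the limit of > 10000 nM in this assay, at which 2 of the 4 values shown sit. The methoxy group is also not needed for a measurable value, although replacing 5-carboxy-2-methoxyphenyl with 4-carboxy-3-chlorophenyl gives a 2.2-fold higher number from compound 3 to compound 4 (0.34 log units; beyond the scatter).

Still open, going by these compounds, is whether 4-carboxy-3-methoxyphenyl or 5-carboxy-2-chlorophenyl would give a lower number than these groups. Also open, on these data alone, is whether an amide could stand in place of the carboxylic acid.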